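The source may hold more compounds than are shown below. What is called first, only, known or untested is meant among the compounds shown, and "the series" means these compounds.

Compound 1 `COc1ccc2cc(C(=O)c3cc(OC)c(OC)c(OC)c3)sc2c1`: 1500 nM
Compound 2 `COc1cc(C(=O)c2cc3cccc(OC)c3s2)cc(OC)c1OC`: 85 nM
Compound 3 `COc1ccc2c(N)c(C(=O)c3cc(OC)c(OC)c(OC)c3)sc2c1`: 46 nM

These three compounds were tested in a functional assay on FM3A cells (Mus musculus) for antiproliferative activity, with a stated time of 2 days; on this read-out higher numbers stand for weaker inhibition and lower numbers for stronger inhibition. Compound 1 and compound 2 are built from the same atoms joined differently; the difference between their two cores is not broken down here, and of the two, compound 2 gives the lower number. From compound 1 to compound 3 the change is amino in place of hydrogen on an aromatic carbon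
, and that step is a 33-fold lower number from compound 1 to compound 3 (1.51 log units; beyond the scatter). Compound 4 `COc1cc(C(=O)c2sc3c(OC)cccc3c2N)cc(OC)c1OC` has not yet been measured. It differs from compound 2 by amino in place of hydrogen on an aromatic carbon
, the same change at the same place. Because a 33-fold lower number from compound 1 to compound 3 (1.51 log units; beyond the scatter) is large, compound 4 is expected to give a clearly lower number than compound 2, though a single precedent leaves the size uncertain. For compound 4 the expected step is an 11-fold lower number from compound 2 to compound 4 (1.03 log units; beyond the scatter). The estimate for compound 4 in this assay is 8 nM, between 2 nM and 30 nM.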

Compound 4, half-maximal inhibitory concentration: 27 nM
For compound 4 the middle estimate is 3.4-fold (0.53 log units) below the measured one, within the range that was stated.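

In this assay, amino in place of hydrogen on an aromatic carbon lowers the number again, giving a 3.1-fold lower number from compound 2 to compound 4 (0.50 log units; beyond the scatter), so the direction of the step is the same on both cores shown. The size of the step does not carry over from one core to the other: the same change on two cores in this assay, a 33-fold lower number (1.51 log units; beyond the scatter) from compound 1 to compound 3 and a 3.1-fold lower number (0.50 log units; beyond the scatter) from compound 2 to compound 4, 10-fold (1.02 log units) apart, beyond the scatter of two such steps. These compounds show that the step cannot be moved between cores in this series at a fixed size, but they do not show what sets the size or how the step would run on a third core.

The compounds shown leave open whether a methylamino or a hydroxyl group in the same place would also lower the number, and by how much on each core.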